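This account rests on a few compounds, and the source may have more. Where it says the series, first, only, none or still open, it means among the compounds named here.

Measured compounds in this series:

compound 1, `COc1cc(C)cc(-c2c(-c3ccnc(-c4ccc(C(C)=O)cc4)c3)cnn2CC#N)c1` — 102%
compound 2, `COc1cc(C)cc(-c2nn(CC#N)cc2-c2ccnc(-c3ccc(N(C)C)cc3)c2)c1` — -15%

In a functional assay on COLO 205 cells (Homo sapiens) for cytotoxicity, read by sulforhodamine B assay, with a stated time of 48 h, tested at 100 nM (a higher number here means a weaker effect of the compound at the concentration tested, a lower number a stronger effect), compound 1 gives 102%, the higher of the two numbers recorded. Compound 2 gives -15% in this assay, and the gap between the two values is beyond the scatter. Among the compounds with values here, the two differ in more than one place; no single-change step between them is available, and the pair shows only that one value is high and the other very low.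

Compound 3, `COc1cc(C)cc(-c2c(-c3ccnc(-c4ccc(N(C)C)cc4)c3)cnn2CC#N)c1`, is compound 1 with one change: dimethylamino in place of acetyl on an aromatic carbon. Within the data shown here, the same dimethylamino group is carried by compound 2, the only other measured compound.

Among the measured compounds shown here, no measured step of this kind exists, so the expectation rests on the two values alone. A large step downward, beyond the scatter, is expected, a number 97 percentage points lower from compound 1 to compound 3 (beyond the scatter). For compound 3 in this assay the estimate is 5%, with a range from -20% to 55%.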

Compound 3, a percentage reported as activity, at one concentration (the size of the read-out at that concentration, not a potency): 7%
Estimate against measurement, compound 3: 2 percentage points below, within the range that was stated.
By their numbers in this assay, from the lowest: compound 2; then compound 3; then compound 1.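

Within the data shown here, replacing acetyl with dimethylamino on the aromatic carbon para to a large group gives a number 95 percentage points lower from compound 1 to compound 3 (beyond the scatter) in this assay, the only single-change step so far. The read-out at this position therefore depends strongly on which group is present, even though the two groups match in heavy-atom count and hydrogen-bond acceptor count, and neither has a donor or a net charge. Nothing available bears on why the read-out moves with this change.

Going by these compounds, whether a primary amine, a carboxylic acid or a methoxy group at the same position would behave like acetyl or like dimethylamino remains open. Also open, on these data alone, is whether the change from 4-acetylphenyl to 4-(dimethylamino)phenyl would have a similar effect on the core of compound 2.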